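A Trimethoxyphenyl Swap in a Weakly Active Series

A few compounds are considered here, and "the series" means these few. Any claim that something is new, unique, unknown or untested is made for them only; others in the source may bear on it.

Three related compounds have been tested so far. In a functional assay on PC-3 cells (Homo sapiens) for inhibition, read by sulforhodamine B assay, with a stated time of 48 h, tested at 50 uM (a higher number here means more inhibition of growth at the concentration tested, a lower number less inhibition of growth), compound 1 (`COc1cc(/C=C/C(=O)/C=C/c2cccc3ccccc23)ccc1OCc1cn(CCCOc2cc(=O)oc3ccccc23)nn1`) gives 8%. Compound 3 (`COc1cccc(/C=C/C(=O)/C=C/c2ccc(OCc3cn(CCOc4cc(=O)oc5ccccc45)nn3)c(OC)c2)c1`) gives 13%, which lies within the usual scatter of the value for compound 1, so the two cannot be told apart. Compound 2 (`COc1cc(/C=C/C(=O)/C=C/c2ccccc2)ccc1OCc1cn(CCCCOc2cc(=O)oc3ccccc23)nn1`) is recorded as "not active" (no number reported), so it offers no number for comparison. Going by the values given here, compound 1 therefore stands level with the only other measured number, and little growth inhibition is seen at the concentration tested.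

Compound 4 (`COc1cc(/C=C/C(=O)/C=C/c2cc(OC)c(OC)c(OC)c2)ccc1OCc1cn(CCCOc2cc(=O)oc3ccccc23)nn1`) keeps the rest of compound 1 and changes one group: 3,4,5-trimethoxyphenyl in place of naphthalen-1-yl on a double-bonded chain carbon bound to a double-bonded chain carbon. Here, 3,4,5-trimethoxyphenyl takes the place of naphthalen-1-yl on a double-bonded chain carbon bound to a double-bonded chain carbon.

Among the compounds with values here, no tested pair differs at only one place, so the data do not measure this change directly. The expectation rests on the close numbers of compound 1 at 8% and compound 3 at 13%, and no step beyond the scatter is expected in this assay. The estimated change is small and upward, a number 5 percentage points higher from compound 1 to compound 4 (within the scatter). The estimate for compound 4 is 13%, with an expected range from 3% to 32%.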

Compound 4, percent growth inhibition at one concentration: 12%
Compound 4: middle estimate off by 1 percentage points, on the high side; low and high end bracket the measured number.
By their numbers in this assay, from the lowest: compounds 1, 4 and 3 (each within the scatter of the next).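

Going by these compounds alone, this is the first pair that differs at only one place, so the effect of a change can now be read directly. In this assay, putting 3,4,5-trimethoxyphenyl in place of naphthalen-1-yl on a double-bonded chain carbon bound to a double-bonded chain carbon gives a number 4 percentage points higher from compound 1 to compound 4 (within the scatter), so the two compounds cannot be told apart, even though the entering group has one aromatic ring instead of two and brings 3 hydrogen-bond acceptors where the leaving group has none. Growth inhibition at the concentration tested stays low with either group, and nothing measured here explains why this swap leaves the read-out so little changed.

Still open is what a phenyl ring carrying an amine or a carboxylic acid would do at this same place, since both groups shown are neutral aromatic groups without hydrogen-bond donors. Also open is whether the swap would read the same with a longer chain in the other part of the molecule, as the compounds shown with other chain lengths differ in more than one place.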